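Replacing 4-methylphenyl with 3-methoxyphenyl on the sulfur-bound carbon

The compounds below may be only part of what the source reports. "The series", "measured", "known", "first", "only" and "open" are said of these compounds alone.

Compound 1, `COc1ccc2cc([C@H](C)c3nnc(SCc4ccc(C)cc4)n3-c3ccc(F)cc3)ccc2c1`, was tested in a functional assay on LNCaP cells (Homo sapiens) for cytotoxicity, read by MTT assay; on this read-out lower numbers stand for stronger inhibition and higher numbers for weaker inhibition. In this assay compound 1 gives only a limit, <= 400000 nM, so its actual potency is not pinned down. Compound 2, `COc1ccc2cc([C@H](C)c3nnc(SCc4ccc(C)cc4)n3-c3ccc(Cl)cc3)ccc2c1`, carries a chloro in place of fluoro on an aromatic carbon, and in this assay compound 2 gives 52200 nM. The step that the limit leaves unreadable from compound 1 to compound 2 cannot be sized because compound 1 sits at the limit of <= 400000 nM in this assay, at which 1 of the 2 values shown sits.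

Compound 3, `COc1cccc(CSc2nnc([C@@H](C)c3ccc4cc(OC)ccc4c3)n2-c2ccc(F)cc2)c1`, differs from compound 1 by 3-methoxyphenyl in place of 4-methylphenyl on a saturated chain carbon bound to a sulfur. Among the compounds with values here, no measured step covers this change: the single measured step, from compound 1 to compound 2, concerns the fluoro-to-chloro exchange and is itself unreadable. Within the data shown here, the expected step that the limit leaves unreadable from compound 1 to compound 3 therefore rests on no precedent and is given as close to no change. For compound 3 the estimate is 200000 nM, within a range from 40000 nM to 400000 nM, with a real chance that this assay again reports only a limit.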

Compound 3, half-maximal inhibitory concentration: 14500 nM
Estimate against measurement, compound 3: 14-fold (1.14 log units) above; measured number outside the range, below it.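

The step from compound 1 to compound 3 cannot be sized, because compound 1 has only a limit in this assay: the limit of <= 400000 nM in this assay, at which 1 of the 3 values shown sits.

The compounds shown leave open how far either change, 3-methoxyphenyl for 4-methylphenyl or chloro for fluoro, shifts potency on its own.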